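From compound 2 to compound 3: a larger amide group

A few compounds are considered here, and "the series" means these few. Any claim that something is new, unique, unknown or untested is made for them only; others in the source may bear on it.

In a functional assay on MCF7 cells (Homo sapiens) for antiproliferative activity, read by MTT assay, with a stated time of 24 h (on this read-out lower numbers stand for stronger inhibition and higher numbers for weaker inhibition), compound 1 `CCn1c(C(=O)NCCC(=O)OC)ccc1C(CC)(CC)c1ccc(OCS(=O)(=O)c2ccccc2)c(C)c1` gives > 50000 nM, which is a limit of the assay and not a number. Within the data shown here, compound 2 `CCn1c(C(=O)NCCCO)ccc1C(CC)(CC)c1ccc(OCS(=O)(=O)c2ccccc2)c(C)c1` gives 42000 nM, the only actual number so far, so there is no second number to rank it against. Compound 3 `CCn1c(C(=O)N[C@@H](CO)CCCO)ccc1C(CC)(CC)c1ccc(OCS(=O)(=O)c2ccccc2)c(C)c1` has not yet been measured and keeps the core of compound 2. The structural change is a group of 7 heavy atoms (5 carbon, 2 oxygen; no ring) in place of a group of 4 heavy atoms (3 carbon, 1 oxygen; no ring), on an amide-type nitrogen, so the 3-hydroxypropyl group leaves the amide-type nitrogen.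

Among the measured compounds shown here, only one measured step bears on this change: an at least 1.1-fold lower number from compound 1 to compound 2 (0.07 log units; that floor lies within the scatter). That step also altered the chain on the amide-type nitrogen, and its floor lies within the scatter. It is a single step of a different kind, so it is only a loose guide and gives no support for expecting a large shift. No change beyond the scatter is therefore expected in this assay, in either direction. The expected step is a 1.1-fold lower number from compound 2 to compound 3 (0.04 log units; within the scatter). Compound 3 is estimated at 38000 nM, with an expected range from 16000 nM to 50000 nM.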

Compound 3, half-maximal inhibitory concentration: 29600 nM
Compound 3: the middle estimate sits 1.3-fold (0.11 log units) above what was measured; low and high end bracket the measured number.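

Compound 3 gives the series a second actual number, so this amide-type nitrogen can now be judged by a true comparison in this assay. Replacing the 3-hydroxypropyl group with the larger group of 7 heavy atoms, which brings a defined stereocentre and 2 hydrogen-bond donors, gives a 1.4-fold lower number from compound 2 to compound 3 (0.15 log units; within the scatter), so this position accepts the larger chain with no change beyond the scatter, and potency stays weak. The comparison with the methoxycarbonyl-bearing chain gives an at least 1.6-fold lower number from compound 1 to compound 3 (0.22 log units; that floor lies within the scatter), which offers only a floor that also lies within the scatter, and compound 1 carries a limit of the assay and not a number: the limit of > 50000 nM in this assay, at which 1 of the 3 values shown sits.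

As far as these compounds go, what an amine, a carboxylic acid or a phenyl ring at the end of the chain on this amide-type nitrogen would do to the number remains open, and so does whether any such group could move it beyond the scatter. Also open, from the compounds shown here alone, is how the opposite configuration at the stereocentre of compound 3 would compare, as is whether a longer chain would behave like the two hydroxyl-bearing chains.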